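The source may report more compounds than this note shows. Statements on the series, on what has been measured and on what is new or still open speak of the compounds shown alone.

Compound 1, `O=C1/C(=C\c2ccccc2)S/C(=N/c2ccccc2)N1Cc1ccncc1`, is the starting point. In a functional assay on MCF7 cells (Homo sapiens) for cytotoxicity, read by MTT assay, with a stated time of 48 h (a lower number here means a stronger inhibitor, a higher number a weaker inhibitor), compound 1 gives 26400 nM, which is the second highest of the three numbers in hand. Its nearest neighbour is compound 3, `COc1cc(/C=C2/S/C(=N/c3ccccc3)N(Cc3ccncc3)C2=O)ccc1O`, which in this assay gives 28000 nM; the step from compound 1 is a 1.1-fold higher number from compound 1 to compound 3 (0.03 log units; within the scatter). The furthest is compound 2, `O=C1/C(=C\c2ccc(O)cc2)S/C(=N/c2ccccc2)N1Cc1ccncc1`, which in this assay gives 18900 nM, a step of a 1.4-fold lower number from compound 1 to compound 2 (0.15 log units; within the scatter). Between the two substituted analogues the step is a 1.5-fold higher number from compound 2 to compound 3 (0.17 log units; within the scatter). All three steps alter the aryl group on the double-bonded chain carbon bound to a double-bonded ring carbon, and none of them moves the number beyond the scatter.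

Compound 4, `O=C1/C(=C\c2ccccn2)S/C(=N/c2ccccc2)N1Cc1ccncc1`, is not yet measured. It differs from compound 1 by pyridin-2-yl in place of phenyl on a double-bonded chain carbon bound to a double-bonded ring carbon. This change touches the same aryl group that the measured steps altered, and those steps were a 1.4-fold lower number from compound 1 to compound 2 (0.15 log units; within the scatter) and a 1.1-fold higher number from compound 1 to compound 3 (0.03 log units; within the scatter), both within the scatter. Among the measured compounds shown here, no measured step replaces the ring itself with a ring bearing a hetero atom, so the data give no direct guide to that. On the evidence available, the step expected in this assay is one of no change beyond the scatter, a 1.0-fold lower number from compound 1 to compound 4 (0.01 log units; within the scatter). Compound 4 is therefore estimated in this assay at 26000 nM, with a range from 10000 nM to 70000 nM.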

Compound 4, half-maximal inhibitory concentration: 21100 nM
Beside the measured number, compound 4's estimate is 1.2-fold (0.09 log units) above it; the range from low to high includes it.
By their numbers in this assay, from the lowest: compounds 2, 4, 1 and 3 (each within the scatter of the next).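

In this assay, the first hetero atom placed in this aryl ring, with pyridin-2-yl in place of phenyl on a double-bonded chain carbon bound to a double-bonded ring carbon, gives a 1.3-fold lower number from compound 1 to compound 4 (0.10 log units; within the scatter) and so adds a hydrogen-bond acceptor without a step beyond the scatter. The earlier compounds had varied only the groups carried on a phenyl ring, whereas this result extends the same flat picture to a change in the ring itself, and the comparisons with the substituted analogues agree, at a 1.3-fold lower number from compound 3 to compound 4 (0.12 log units; within the scatter) and a 1.1-fold higher number from compound 2 to compound 4 (0.05 log units; within the scatter), so that none of the four aryl groups shown is separated from another in this assay. No supporting measurement is available to account for this result.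

The compounds shown leave open whether pyridin-3-yl or pyridin-4-yl at this place, or an amine or a carboxylic acid on the aryl ring, would give a step beyond the scatter. They also leave open what a change elsewhere would do, for instance a longer chain in place of the pyridin-4-ylmethyl group, which stays the same in all four compounds.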